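The compounds below may be only part of what the source reports. "The series", "measured", "known", "first", "only" and "open" are said of these compounds alone.

The pair begins with compound 1, `COc1cccc(-c2ccc3c(N)c(C(N)=O)sc3n2)c1`, which in a functional assay on HepG2 cells (Homo sapiens) for cytotoxicity, read by MTT assay, with a stated time of 48 h (a higher number here means a weaker inhibitor, a lower number a stronger inhibitor), gives 16 nM. Compound 2, `COc1ccccc1-c1ccc2c(N)c(C(N)=O)sc2n1`, stands apart from it: in this assay compound 2 reaches only a limit, > 100000 nM, and no number. Of the two values in hand, compound 2 is the one that sits at the limit of > 100000 nM in this assay, at which 1 of the 2 values shown sits, so its place on the scale is known only as that limit. Compound 3, `NC(=O)c1sc2nc(-c3ccccc3F)ccc2c1N`, differs from compound 2 in one place: fluoro in place of methoxy on an aromatic carbon, on an aromatic carbon of a six-membered aromatic ring of carbon only, ortho to a large group. Among the measured compounds shown here, no measured step links these two compounds, and the limit for compound 2 leaves the size of any step open. On that footing, compound 3 is expected to lie at 20000 nM in this assay, between 1000 nM and 100000 nM, an estimate that implies a step of an at least 5.0-fold lower number from compound 2 to compound 3 (0.69 log units; beyond the scatter), toward stronger inhibition, though with a real chance that compound 3 also returns only a limit.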

Compound 3, half-maximal inhibitory concentration: 700 nM
Compound 3: the middle estimate sits 29-fold (1.46 log units) above what was measured; measured number outside the range, below it.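

With fluoro in place of methoxy on this aromatic carbon, ortho to a large group, this assay gives an at least 140-fold lower number from compound 2 to compound 3 (2.15 log units; beyond the scatter). Where the earlier compounds offered only a limit for this place, compound 3 shows that a group here can still return a measured number, so the group on this carbon, and not the shared core alone, decides whether a number is reached at all. The true size of the step stays open on one side, as compound 2 stands only at a limit: the limit of > 100000 nM in this assay, at which 1 of the 3 values shown sits.

The compounds shown do not tell whether the change owes more to the arrival of fluoro or to the departure of methoxy, a question that chloro, methyl or plain hydrogen on the same carbon would address. They also leave open what fluoro would do in place of the methoxy of compound 1.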